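Difluorophenyl in Place of Pyridyl on the Piperazine Nitrogen

This account rests on a few compounds, and the source may have more. Where it says the series, first, only, none or still open, it means among the compounds named here.

Of the compounds shown here, two of one series have so far been tested in an assay on CHO cells for displacement of a labelled ligand from adenosine receptor A1 (Homo sapiens), read by scintillation counting, with a stated time of 120 min, tested at 10 uM; a higher number here means more inhibition at the concentration tested (going by the name of the read-out), a lower number less inhibition. Compound 1 `Nc1scc(CN2CCN(c3ccncc3)CC2)c1C(=O)c1ccc(Cl)cc1` gives 1% in this assay. Compound 2 `Nc1scc(CN2CCN(c3c(F)cccc3F)CC2)c1C(=O)c1cccc(C(F)(F)F)c1` gives 0% in this assay. Compound 1 holds the higher of the two numbers, but the gap to compound 2 lies within the scatter, so the two cannot be told apart; both show essentially no displacement at the concentration tested.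

Compound 3 `Nc1scc(CN2CCN(c3cc(F)ccc3F)CC2)c1C(=O)c1ccc(Cl)cc1` has not yet been measured. It differs from compound 1 in one place: 2,5-difluorophenyl in place of pyridin-4-yl on an amine nitrogen in a ring. For the measured compounds named here, no step between measured compounds bears on this change, so any expectation rests on the two values alone. Given that compound 1 sits at 1% and compound 2, which also carries a difluorophenyl group, sits at 0%, the change is expected to bring no step beyond the scatter. The expected step of a number 1 percentage points higher from compound 1 to compound 3 (within the scatter) is therefore flat. Compound 3 is estimated to show 2% in this assay, within a range from -5% to 12%.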

Compound 3, a percentage reported as inhibition, at one concentration (the size of the read-out at that concentration, not a potency): 1%
Compound 3: middle estimate off by 1 percentage points, on the high side; the range from low to high includes it.
By their numbers in this assay, from the lowest: compounds 2, 1 and 3 (each within the scatter of the next).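

In this assay, placing 2,5-difluorophenyl in place of pyridin-4-yl on the amine nitrogen in the ring brings no change at the digits printed from compound 1 to compound 3 (within the scatter). Compound 1 and compound 2 differ in more than one place, so this is the only pair shown that reads the change at this position on its own. It shows that replacing the six-membered aromatic ring with one nitrogen by a carbon-only aromatic ring bearing two fluorines, which also removes the hydrogen-bond acceptor counted on the leaving group, does not lift the reading from its level of almost no inhibition, although a reading this close to nothing says little about how either group would behave in a compound with measurable displacement.

Going by these compounds, whether a non-aromatic group on the same nitrogen, such as a carboxylic acid or a longer chain ending in an amine, would give a higher number in this assay remains open. No measurement is available that explains the absence of a step between these two groups.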